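From 1H-indol-6-yl to 1-methyl-1H-indol-3-yl

The source may report more compounds than this note shows. Statements on the series, on what has been measured and on what is new or still open speak of the compounds shown alone.

Measured compounds:
compound 1 `COc1cc(-c2ccnc3cc(-c4ccc5cc[nH]c5c4)nn23)cc(OC)c1OC`: 125 nM
compound 3 `COc1cc(-c2ccnc3cc(-c4ccc(N(C)C)cc4)nn23)cc(OC)c1OC`: 378 nM
compound 2 `Cc1ccc(-c2cc3nccc(-c4ccc(F)cc4)n3n2)cc1`: > 10000 nM, a limit of the assay rather than a number

All three were tested in a functional assay on HeLa cells (Homo sapiens) for inhibition, read by CCK-8 assay, with a stated time of 48 h; on this read-out higher numbers stand for weaker inhibition and lower numbers for stronger inhibition. Compound 1 gives the lowest of the two numbers shown. Among the compounds with values here, its nearest neighbour is compound 3, and the step of a 3.0-fold higher number from compound 1 to compound 3 (0.48 log units; beyond the scatter) is the only one-place change measured here. For compound 2 the assay reports only a limit, as recorded in the limit of > 10000 nM in this assay, at which 1 of the 3 values shown sits, so no number can be set against it.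

The unmeasured compound 4 `COc1cc(-c2ccnc3cc(-c4cn(C)c5ccccc45)nn23)cc(OC)c1OC` differs from compound 1 in the same position: 1-methyl-1H-indol-3-yl in place of 1H-indol-6-yl on an aromatic carbon. Within the data shown here, the only measured step that bears on this position is the modest rise seen in a 3.0-fold higher number from compound 1 to compound 3 (0.48 log units; beyond the scatter), where a different aromatic group replaced the 1H-indol-6-yl. Compound 4 keeps a two-ring aromatic group of the same kind but changes its attachment and carries a methyl on the ring nitrogen. Among the measured compounds shown here, no measured pair shows this exact change, so the expectation is uncertain, but a small loss, smaller than or near that step, seems most likely. The expected change is a 2.0-fold higher number from compound 1 to compound 4 (0.30 log units; within the scatter). Compound 4 is therefore estimated at 250 nM, within 70 nM to 900 nM.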

Compound 4, half-maximal inhibitory concentration: 399 nM
Compound 4: the middle estimate sits 1.6-fold (0.20 log units) below what was measured; the measured number falls inside the stated range.
By their numbers in this assay, from the lowest: compound 1; then compounds 3 and 4 (each within the scatter of the next). At a limit, above all of these: compound 2.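

Replacing 1H-indol-6-yl with 1-methyl-1H-indol-3-yl in this assay gives a 3.2-fold higher number from compound 1 to compound 4 (0.50 log units; beyond the scatter) and so adds a second group on this aromatic carbon that does not match compound 1. This two-ring group and the one-ring 4-(dimethylamino)phenyl cannot be told apart, as the comparison gives a 1.1-fold higher number from compound 3 to compound 4 (0.02 log units; within the scatter) and this gap stays within the scatter. Keeping an indole with the same ring types is therefore not enough on its own to retain the number of compound 1, although the new group also differs in two ways at once: its attachment changes and its ring nitrogen carries a methyl.

The compounds shown leave open which of those two differences matters, a question that 1H-indol-3-yl and 1-methyl-1H-indol-6-yl would separate, and how this position responds to a group of another kind, such as an aliphatic amine or a carboxylic acid. Nothing measured here gives a reason for either step.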